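Anilide halogen change on two core variants

The compounds below may be only part of what the source reports. "The series", "measured", "known", "first", "only" and "open" are said of these compounds alone.

Measured so far:
compound 1 `O=C(CN1CCN(c2nnc(Cc3ccncc3)c3ccccc23)CC1)Nc1cccc(F)c1` — in a functional assay on A549 cells (Homo sapiens) for cytotoxicity, read by MTT assay, with a stated time of 72 h (a lower number here means a stronger inhibitor, a higher number a weaker inhibitor), compound 1 gives 4600 nM
compound 2 `O=C(CN1CCN(c2nnc(Cc3ccncc3)c3ccccc23)CC1)Nc1ccc(F)c(Cl)c1` — compound 2 gives 12300 nM
compound 3 `O=C(CN1CCN(c2nnc(Cc3ccccc3)c3ccccc23)CC1)Nc1cccc(F)c1` — compound 3 gives 130000 nM

Compounds 1 and 2 share one core and differ only at the anilide: 3-chloro-4-fluorophenyl in place of 3-fluorophenyl on an amide-type nitrogen. That change gives a 2.7-fold higher number from compound 1 to compound 2 (0.43 log units; beyond the scatter). Compound 3 carries a different core; the difference from compound 1 is phenyl in place of pyridin-4-yl on a saturated chain carbon bound to an aromatic carbon, and the step is a 28-fold higher number from compound 1 to compound 3 (1.45 log units; beyond the scatter), leaving compound 3 with the highest number of the three.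

Compound 4 `O=C(CN1CCN(c2nnc(Cc3ccccc3)c3ccccc23)CC1)Nc1ccc(F)c(Cl)c1` has not been measured. It stands to compound 3 as compound 2 stands to compound 1: 3-chloro-4-fluorophenyl in place of 3-fluorophenyl on an amide-type nitrogen. The place is the same in both pairs, so this is the same change made on the other core.

Among the compounds with values here, for compound 4 the expected step from compound 3 is a 2.3-fold higher number from compound 3 to compound 4 (0.36 log units; beyond the scatter), a modest rise like the one already seen, resting on a 2.7-fold higher number from compound 1 to compound 2 (0.43 log units; beyond the scatter) in the first pair; with only one earlier instance, the size is uncertain. Compound 3 already sits at 130000 nM, the highest number of the three, so the expected number for compound 4 is higher still. The estimate for compound 4 in this assay is 300000 nM, expected to fall between 100000 nM and 1000000 nM.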

Compound 4, half-maximal inhibitory concentration: "not active" (no number reported)
Compound 4: no number reported; there is nothing to compare the estimate with.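

Within the data shown here, compound 4 is reported as not active in this assay, without a number, and no step from compound 3 to compound 4 can be read. No measured evidence bears on this result. The compounds shown leave open whether a 2.7-fold higher number from compound 1 to compound 2 (0.43 log units; beyond the scatter) carries over in size to the core of compound 3.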